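Kinetic Solubility Across Three Related Compounds

This account rests on a few compounds, and the source may have more. Where it says the series, first, only, none or still open, it means among the compounds named here.

Measured so far:
compound 1 `Cc1ccc(C)c(-c2nc(CN3CCC(C(=O)NCCCN4C[C@H](C)C[C@H](C)C4)CC3)c(C)o2)c1`: 56.1 ug/mL
compound 2 `Cc1ccccc1-c1nc(CN2CCC(C(=O)NCCCN3CCC(C)CC3)CC2)c(C)o1`: > 67 ug/mL

Compound 1, with the structure `Cc1ccc(C)c(-c2nc(CN3CCC(C(=O)NCCCN4C[C@H](C)C[C@H](C)C4)CC3)c(C)o2)c1`, was measured in a physicochemical assay for solubility, in phosphate buffer, measured as kinetic solubility, at pH 7.4 (on this read-out higher numbers stand for higher solubility and lower numbers for lower solubility), where compound 1 gives 56.1 ug/mL. Compound 2 `Cc1ccccc1-c1nc(CN2CCC(C(=O)NCCCN3CCC(C)CC3)CC2)c(C)o1` gives in this assay a read-out of > 67 ug/mL, which is a limit of the assay and not a number, as recorded in the limit of > 67 ug/mL in this assay, at which 1 of the 2 values shown sits. Compound 2 therefore stands at the upper edge of the numbers shown, and how far beyond that edge it lies is unknown. Compound 3 `Cc1ccccc1-c1nc(CN2CCC(C(=O)NCCCN3CCCC(CC(C)C)C3)CC2)c(C)o1` has not yet been measured in this assay. It differs from compound 2 by a group of 10 heavy atoms (9 carbon, 1 nitrogen; one six-membered non-aromatic ring with 1 hetero atom) in place of a group of 7 heavy atoms (6 carbon, 1 nitrogen; one six-membered non-aromatic ring with 1 hetero atom), on a saturated chain carbon, three bonds along the chain from an amide-type nitrogen. For the measured compounds named here, no step between measured compounds exists here to guide the size of this change. Still, the step of an at least 2.2-fold lower number from compound 2 to compound 3 (0.34 log units; beyond the scatter) is expected to be a fall that goes beyond the usual scatter. Compound 3 is accordingly estimated to give 30 ug/mL, within a range from 10 ug/mL to 67 ug/mL.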

Compound 3, solubility: 54.9 ug/mL
Compound 3: the middle estimate sits 1.8-fold (0.26 log units) below what was measured; measured number inside the range.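

In this assay, for the compounds shown here, putting the group of 10 heavy atoms in place of 4-methylpiperidin-1-yl, on a saturated chain carbon, three bonds along the chain from an amide-type nitrogen, gives the first step at this position: an at least 1.2-fold lower number from compound 2 to compound 3 (0.08 log units; that floor lies within the scatter). With the larger group, compound 3 gives a number, 54.9 ug/mL, so this change now has one end that is a measured value. The other end remains a limit of the assay, so the true size of the step cannot be read and only its floor is known: the limit of > 67 ug/mL in this assay, at which 1 of the 3 values shown sits.

The compounds shown leave open how far beyond its limit compound 2 lies, and so whether this change moves the read-out beyond the scatter at all. They also leave open what a diethylamino group or a carboxylic acid would give at this position.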